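A few compounds are considered here, and "the series" means these few. Any claim that something is new, unique, unknown or untested is made for them only; others in the source may bear on it.

Compound 1 `CCN(CC)CCCNc1ccnc2cc(Cl)ccc12` is the simplest member of the set; in a functional assay on MCF7 cells (Homo sapiens) for antiproliferative activity, read by sulforhodamine B assay, with a stated time of 48 h (on this read-out lower numbers stand for stronger inhibition of growth and higher numbers for weaker inhibition of growth), compound 1 gives 17900 nM. Compound 2 `Clc1ccc2c(NCCCN3CCN(c4ccnc5cc(Cl)ccc45)CC3)ccnc2c1` joins two copies of the core through a longer linker; in this assay compound 2 gives 5420 nM. Compound 1 shows the highest of the three numbers, with compound 2 the nearest and that gap beyond the scatter. The difference between the core of compound 1 and that of compound 2 is not broken down here. Compound 3 `FC(F)(F)c1ccc2c(N3CCN(CCCNc4ccnc5cc(Cl)ccc45)CC3)ccnc2c1` differs from compound 2 by trifluoromethyl in place of chloro on an aromatic carbon; in this assay compound 3 gives 4990 nM, so that a 1.1-fold lower number from compound 2 to compound 3 (0.04 log units; within the scatter). Compound 4 `CCN(CC)CCCNc1ccnc2cc(C(F)(F)F)ccc12` differs from compound 1 by the same change, (trifluoromethyl in place of chloro on an aromatic carbon), at a place described in identical words. The step from compound 1 to compound 4 is expected to be small, a 1.1-fold lower number from compound 1 to compound 4 (0.05 log units; within the scatter), because a 1.1-fold lower number from compound 2 to compound 3 (0.04 log units; within the scatter) stays within the scatter and no other instance of this change is available. Compound 4 is therefore expected to give 16000 nM in this assay, with an expected range of 7500 nM to 34000 nM.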

Compound 4, concentration for 50% growth inhibition: 20600 nM
For compound 4 the middle estimate is 1.3-fold (0.11 log units) below the measured one; measured number inside the range.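

In this assay, trifluoromethyl in place of chloro on an aromatic carbon of the core of compound 1 gives a 1.2-fold higher number from compound 1 to compound 4 (0.06 log units; within the scatter), so the two values cannot be told apart. Set beside the earlier step, the change reads alike on both cores: the same change on two cores in this assay, a 1.1-fold lower number (0.04 log units; within the scatter) from compound 2 to compound 3 and a 1.2-fold higher number (0.06 log units; within the scatter) from compound 1 to compound 4, 1.3-fold (0.10 log units) apart, within the scatter of two such steps Within this series, the change can therefore be carried between these two cores as a step within the scatter, but this rests on only two pairs in a single assay, and it does not show that the same would hold on any other core or in any other read-out.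

The compounds shown leave open whether a group other than chloro or trifluoromethyl at this place, such as a nitrile or a methoxy group, would give a step beyond the scatter. They also leave open whether a longer chain in the linker would alter the size of the step seen here.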